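The source may hold more compounds than are shown below. What is called first, only, known or untested is meant among the compounds shown, and "the series" means these compounds.

Compound 1 `NS(=O)(=O)c1ccc(/C=C/c2ccc(O)c(O)c2)cc1` gives 29900 nM
Compound 2 `NS(=O)(=O)c1ccc(/C=C/c2ccc(F)cc2)cc1` gives 26700 nM
Compound 3 `NS(=O)(=O)c1ccc(/C=C/c2ccc(O)cc2)cc1` is not yet measured

In a functional assay on LOX IMVI cells (Homo sapiens) for inhibition (on this read-out higher numbers stand for weaker inhibition of growth and lower numbers for stronger inhibition of growth), compound 2 gives 26700 nM as its value, within the scatter of compound 1 (29900 nM), so the two cannot be told apart. Compound 3 has hydroxy in place of fluoro on an aromatic carbon, para to a large group (hydroxy in place of fluoro on an aromatic carbon). Among the measured compounds shown here, no measured pair shows this exchange directly. Compound 1 also carries hydroxy and gives 29900 nM on the same scale, so no step beyond the scatter is expected, in either direction. The expected 1.0-fold higher number from compound 2 to compound 3 (0.00 log units; within the scatter) would be small, an estimate only. Compound 3 is expected at 27000 nM (estimated range 11000 nM to 65000 nM).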

Compound 3, concentration for 50% growth inhibition: 19100 nM
Estimate against measurement, compound 3: 1.4-fold (0.15 log units) above; measured number inside the range.
By their numbers in this assay, from the lowest: compounds 3, 2 and 1 (each within the scatter of the next).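

In this assay hydroxy in place of fluoro on an aromatic carbon, para to a large group, gives a 1.4-fold lower number from compound 2 to compound 3 (0.15 log units; within the scatter) and so does not separate the two compounds in this first direct look at the exchange. Hydrogen in place of one hydroxy of compound 1 gives a 1.6-fold lower number from compound 1 to compound 3 (0.19 log units; within the scatter) and likewise separates nothing. No measurement here offers an explanation for these small steps. Open, going by these compounds, is whether another group at this place, such as an amine or a carboxylic acid, would move the number beyond the scatter.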